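A Sulfur Substituent Changed on a Weak Growth Inhibitor

The compounds below may be only part of what the source reports. "The series", "measured", "known", "first", "only" and "open" are said of these compounds alone.

For the measured compounds named here, in a functional assay on DU-145 cells (Homo sapiens) for inhibition, read by trypan blue exclusion, with a stated time of 96 h (on this read-out higher numbers stand for weaker inhibition of growth and lower numbers for stronger inhibition of growth), compound 1 (`CCOc1ccc(/C=C(/Sc2ccccc2Cl)C(=O)c2ccc(Cl)cc2)cc1OC`) gives 50000 nM and holds the higher of the two numbers so far, which means the weaker inhibition of growth. Compound 2 (`O=C(/C(=C\OCc1ccccc1)S(=O)(=O)c1ccccc1Cl)c1ccc(Cl)cc1`) gives 1000 nM and lies below compound 1 by a gap beyond the scatter. Compound 3 (`CCOc1ccc(/C=C(/SCc2ccc(Cl)c(Cl)c2)C(=O)c2ccc(Cl)cc2)cc1OC`) keeps the rest of compound 1 but carries 3,4-dichlorobenzyl in place of 2-chlorophenyl on a sulfur. Going by the values given here, no two measured compounds differ in only one place, so the data offer no direct precedent for this change. The expectation rests on two values alone: compound 1 at 50000 nM has ample room to fall, and compound 2 at 1000 nM shows that a much lower number is reachable in this small set. A moderate step toward stronger inhibition of growth, beyond the scatter, is therefore expected, estimated as a 5.0-fold lower number from compound 1 to compound 3 (0.70 log units; beyond the scatter) on this slender evidence. For compound 3 the expected value is 10000 nM with an estimated range of 2000 nM to 50000 nM in this assay once it is measured.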

Compound 3, concentration for 50% growth inhibition: 25000 nM
Estimate against measurement, compound 3: 2.5-fold (0.40 log units) below; the measured number falls inside the stated range.
By their numbers in this assay, from the lowest: compound 2; then compounds 3 and 1 (each within the scatter of the next).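

For the compounds shown here, the exchange of 2-chlorophenyl for 3,4-dichlorobenzyl on a sulfur gives the first comparison in this assay in which only one place differs, and it reads as a 2.0-fold lower number from compound 1 to compound 3 (0.30 log units; within the scatter). At this sulfur, whose other neighbour is the double-bonded chain carbon, a group of 9 heavy atoms with 2 chlorine can therefore stand in place of one of 7 heavy atoms with 1 chlorine without separating the two compounds beyond the usual scatter, so compound 3 stays level with compound 1 on this read-out. No separate measurement bears on this result.

Still open, going by these compounds, is how the two parts of this exchange would read apart, since 2-chlorobenzyl on the same sulfur would separate the added carbon from the change in the chlorines on the ring. Also open, on these data alone, is whether a quite different substituent at this place, such as a 2-aminoethyl or a carboxymethyl group, would move the number beyond the scatter from that of compound 1.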